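The source may hold more compounds than are shown below. What is called first, only, known or untested is meant among the compounds shown, and "the series" means these compounds.

Three compounds have been measured so far in a functional assay on U2OS cells for antagonist activity at C-X-C chemokine receptor type 3 (Homo sapiens), read by beta-arrestin recruitment; on this read-out lower numbers stand for stronger inhibition and higher numbers for weaker inhibition:

- Compound 1, `CC[C@@H]1CN(c2scnc2-c2nc3ccccc3[nH]2)CCN1C(=O)Cn1cnc2cccnc21`, gives 604 nM
- Compound 2, `Cc1nc(C)n(CC(=O)N2CCN(c3sc(C(F)(F)F)nc3-c3cnc(OC(C)C)nc3)C[C@H]2C)n1`, gives 138 nM
- Compound 3, `Cc1nc(C)n(CC(=O)N2CCN(c3sc(C(F)(F)F)nc3-c3cnc(OC4CCC4)nc3)C[C@H]2C)n1`, gives 78 nM

Compound 3 holds the lowest of these three numbers. Its nearest neighbour is compound 2, whose number lies within the scatter of compound 3, so the two cannot be told apart on this read-out; compound 1 sits clearly higher, beyond the scatter. Going by the values given here, the one step recorded between single-change neighbours, a 1.8-fold lower number from compound 2 to compound 3 (0.25 log units; within the scatter), is itself within the scatter, so exchanging one small group for another on the oxygen of the shared core left the number essentially unchanged.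

Compound 4, `CCCc1ncc(-c2nc(C(F)(F)F)sc2N2CCN(C(=O)Cn3nc(C)nc3C)[C@H](C)C2)cn1`, carries a different kind of change: propyl in place of cyclobutyloxy on an aromatic carbon. Here the oxygen link itself disappears and a plain chain takes the place of the ring-bearing group. Among the compounds with values here, no measured pair covers this exchange; the only step at this position kept the oxygen and stayed within the scatter. With nothing to point to a large move, the expectation for compound 4 is a step of a 1.9-fold higher number from compound 3 to compound 4 (0.28 log units; within the scatter), most likely within or only a little beyond the scatter. Compound 4 is therefore estimated at 150 nM in this assay, with a likely range from 50 nM to 450 nM.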

Compound 4, half-maximal inhibitory concentration: 258 nM
The estimate for compound 4 lay 1.7-fold (0.24 log units) below the measured number, within the range that was stated.
By their numbers in this assay, from the lowest: compounds 3, 2 and 4 (each within the scatter of the next, the first and the last beyond it); then compound 1.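

In this assay, this position now shows its first change that reads beyond the scatter: replacing cyclobutyloxy with a plain propyl, which removes both the oxygen link and the four-membered ring, gives a 3.3-fold higher number from compound 3 to compound 4 (0.52 log units; beyond the scatter) as a modest step. Measured against isopropoxy, the same propyl gives a 1.9-fold higher number from compound 2 to compound 4 (0.27 log units; within the scatter) and so cannot be told apart from that group, which means the oxygen link is not shown to be required; the separation appears only against cyclobutyloxy. No supporting measurement bears on what lies behind these numbers, so they stand here as a description only.

The compounds shown cannot say whether the oxygen or the ring accounts for the step from cyclobutyloxy to propyl; a propoxy group, which keeps the oxygen without a ring, and a cyclobutyl group joined directly to the aromatic carbon, which keeps the ring without the oxygen, would divide the two. Also open, as far as these compounds go, is how this carbon responds to a longer chain such as pentyl, or to a nitrogen link such as cyclobutylamino.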